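A few compounds are considered here, and "the series" means these few. Any claim that something is new, unique, unknown or untested is made for them only; others in the source may bear on it.

Of the compounds shown here, two that share the same core have been measured in an assay on isolated protein for inhibition of Polyunsaturated fatty acid 5-lipoxygenase (Homo sapiens), read by ELISA, with a stated time of 10 min; on this read-out higher numbers stand for weaker inhibition and lower numbers for stronger inhibition. Compound 1 `COC1=CC(=O)C=C(Br)C1=O` gives 1670 nM in this assay. Compound 2 `CCCCCCCCCCCC1=CC(=O)C=C(OC)C1=O` carries an undecyl chain on that core, and in this assay compound 2 gives 340 nM. Of the two numbers, that of compound 2 is the lower one; the number for compound 1 stands higher by a margin beyond the usual scatter of repeated measurements.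

Compound 3 `CCCCCC1=CC(=O)C=C(OC)C1=O` has not yet been measured in this assay. It differs from compound 2 in a single place: hydrogen in place of hexyl on a saturated chain carbon, five bonds along the chain from a double-bonded ring carbon. Within the data shown here, no pair of measured compounds differs in exactly this way, so the size of the step cannot be read from a measured pair. Still, the shorter chain is expected to give a higher number, because compound 2 with its longer chain gives 340 nM while compound 1 gives 1670 nM. The step is expected to be a 2.5-fold higher number from compound 2 to compound 3 (0.40 log units; beyond the scatter), a modest loss beyond the scatter. Compound 3 is therefore estimated at 850 nM, with a range from 300 nM to 2500 nM.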

Compound 3, half-maximal inhibitory concentration: 1370 nM
Compound 3: the middle estimate sits 1.6-fold (0.21 log units) below what was measured; low and high end bracket the measured number.
By their numbers in this assay, from the lowest: compound 2; then compounds 3 and 1 (each within the scatter of the next).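

In this assay, hydrogen in place of hexyl on a saturated chain carbon, five bonds along the chain from a double-bonded ring carbon, now has a measured size (a 4.0-fold higher number from compound 2 to compound 3 (0.61 log units; beyond the scatter)), and it lies beyond the scatter. The outer part of the undecyl chain of compound 2 therefore matters on this read-out, and the presence of a pentyl chain on the shared core does not by itself bring the number down to that of compound 2. Pentyl in place of bromo on a double-bonded ring carbon (a 1.2-fold lower number from compound 1 to compound 3 (0.09 log units; within the scatter)) stays within the scatter, so compound 3 and compound 1 cannot be told apart here.

The compounds shown leave open how the number runs for chains of intermediate length between pentyl and undecyl, and whether a longer chain than undecyl would carry it further in either direction. They also leave open whether a carboxylic acid or an amine at the end of the chain would be compatible with the number of compound 2. Nothing available here gives a measured reason for either step.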